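Amino in place of butoxy on the carbonyl carbon

The source may hold more compounds than are shown below. What is called first, only, known or untested is meant among the compounds shown, and "the series" means these compounds.

Measured so far in a functional assay on SK-BR-3 cells (Homo sapiens) for cytotoxicity, read by resazurin assay, with a stated time of 72 h; on this read-out higher numbers stand for weaker inhibition and lower numbers for stronger inhibition:
compound 1 `CC(=O)CCSC(=S)NCc1cccnc1` gives 1120 nM
compound 2 `CCCCOC(=O)CCSC(=S)NCc1cccnc1` gives 4460 nM

Both compounds share the same core and differ only in the group attached to the carbonyl carbon. For the measured compounds named here, compound 2 stands as the higher of the two numbers, that is, the weaker inhibitor; the one step recorded, a 4.0-fold higher number from compound 1 to compound 2 (0.60 log units; beyond the scatter), was the exchange of butoxy for methyl at that position.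

Compound 3 `NC(=O)CCSC(=S)NCc1cccnc1` has not yet been tested. It differs from compound 2 by amino in place of butoxy on a carbonyl carbon. Going by the values given here, the only measured step that bears on this change is the one from compound 1 to compound 2, since it concerns the same carbonyl carbon and there it moved the number by a 4.0-fold higher number from compound 1 to compound 2 (0.60 log units; beyond the scatter). Removing butoxy again, now for a small group, is therefore expected to bring the number back toward the range of compound 1, though nothing measured shows how an amino group behaves here, so the expectation is loose.

On that basis compound 3 is estimated at 1500 nM in this assay, with a range of 500 nM to 5000 nM, which would mean a step of a 3.0-fold lower number from compound 2 to compound 3 (0.47 log units; beyond the scatter).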

Compound 3, half-maximal inhibitory concentration: 1160 nM
Compound 3: middle estimate off by 1.3-fold (0.11 log units), on the high side, within the range that was stated.
By their numbers in this assay, from the lowest: compounds 1 and 3 (each within the scatter of the next); then compound 2.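

In this assay, amino in place of butoxy on the carbonyl carbon gives a 3.8-fold lower number from compound 2 to compound 3 (0.58 log units; beyond the scatter), so a second, different replacement of butoxy also comes with a lower number. Amino in place of methyl gives a 1.0-fold higher number from compound 1 to compound 3 (0.02 log units; within the scatter), which means that this read-out does not tell these two groups apart at this position, while compound 2, with its butoxy group, remains the weakest of the three compounds. The data show what happens when these groups are exchanged, but no measurement here explains why the butoxy compound differs from the other two.

The compounds shown leave open whether the weaker result of compound 2 goes with the length of the butyl chain or with the oxygen that links it to the carbonyl carbon, a question that methoxy and butylamino groups at the same place could help separate. For the compounds shown here, it is also open how far this position tolerates other kinds of group, such as a carboxylic acid or a dimethylamino group, since amino and methyl are the only small groups represented here.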